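Swapping 3-chlorobenzyl for 4-chlorophenyl: an expected result

The source may hold more compounds than are shown below. What is called first, only, known or untested is meant among the compounds shown, and "the series" means these compounds.

Compound 1 `CC(C)CCn1cnc2c(Nc3ccc(Cl)cc3)nc(N[C@H]3CC[C@H](N)CC3)nc21`: 2700 nM
Compound 2 `N[C@H]1CC[C@H](Nc2nc(Nc3ccc(Cl)cc3)c3ncn(C4CCCCC4)c3n2)CC1`: 2300 nM
Compound 3 `CCCCn1cnc2c(NCc3cccc(Cl)c3)nc(N[C@H]3CC[C@H](N)CC3)nc21`: 2200 nM

These three compounds were tested in a functional assay on MCF7 cells (Homo sapiens) for inhibition, read by fluorescence, with a stated time of 72 h; a higher number here means a weaker inhibitor of growth, a lower number a stronger inhibitor of growth. Compound 3, at 2200 nM, lies within the usual scatter of both other compounds, so the three cannot be ranked.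

Compound 4 `CCCCn1cnc2c(Nc3ccc(Cl)cc3)nc(N[C@H]3CC[C@H](N)CC3)nc21` differs from compound 3 in one place: 4-chlorophenyl in place of 3-chlorobenzyl on a nitrogen on an aromatic ring. In words, 4-chlorophenyl stands in place of 3-chlorobenzyl on a nitrogen on an aromatic ring. Within the data shown here, no measured pair shows this exact change. Among the measured compounds shown here, the one measured step, a 1.2-fold lower number from compound 1 to compound 2 (0.07 log units; within the scatter), concerns cyclohexyl in place of isopentyl on an aromatic nitrogen, so it bears only indirectly, showing little movement among compounds with 4-chlorophenyl. Compound 1 carries that same group and gives 2700 nM, and compound 2 carries it and gives 2300 nM.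

A shift beyond the scatter is therefore not expected, and the expected change is a 1.1-fold higher number from compound 3 to compound 4 (0.06 log units; within the scatter). For compound 4 the estimated value is 2500 nM, with an expected range of 1200 nM to 5000 nM.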

Compound 4, concentration for 50% growth inhibition: 2100 nM
Compound 4: the middle estimate sits 1.2-fold (0.08 log units) above what was measured, within the range that was stated.
By their numbers in this assay, from the lowest: compounds 4, 3, 2 and 1 (each within the scatter of the next).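

In this assay, among these compounds, the change on this nitrogen gives a 1.0-fold lower number from compound 3 to compound 4 (0.02 log units; within the scatter), so with butyl held fixed, the (3-chlorobenzyl)amino and (4-chlorophenyl)amino compounds cannot be told apart, a direct comparison that no earlier pair offered. Compound 4 also extends the series with 4-chlorophenyl held fixed: butyl in place of cyclohexyl gives a 1.1-fold lower number from compound 2 to compound 4 (0.04 log units; within the scatter), and hydrogen in place of methyl on the isopentyl chain gives a 1.3-fold lower number from compound 1 to compound 4 (0.11 log units; within the scatter), so all three groups on the aromatic nitrogen remain within the scatter. Nothing available explains this flat picture.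

The swap alters both the carbon link and the place of the chlorine, so 3-chlorophenyl and 4-chlorobenzyl would be needed to separate the two changes. Going by these compounds, whether an amine, a carboxylic acid or a longer chain at this nitrogen would shift the number remains open.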